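The source may hold more compounds than are shown below. What is called first, only, known or untested is meant among the compounds shown, and "the series" means these compounds.

Compound 1 `CS(=O)(=O)c1ccc(C(=O)N2CCC(C(=O)N3CCN(c4ccc(F)cc4)CC3)CC2)cc1[N+](=O)[O-]` – > 27000 nM
Compound 2 `CN(Cc1cccc(F)c1)C(=O)CCCNC(=O)c1ccc(S(C)(=O)=O)c([N+](=O)[O-])c1` – > 27000 nM
Compound 3 `CS(=O)(=O)c1ccc(C(=O)NCCC(=O)N2CCCCC2)cc1[N+](=O)[O-]` – > 27000 nM

Three compounds sharing the same core were tested in an ADME assay on HepG2 cells (Homo sapiens) for cytotoxicity, read by CellTiter-Glo and ATP content, with a stated time of 72 h; on this read-out lower numbers stand for an effect already at smaller amounts and higher numbers for an effect only at larger amounts of compound. Compound 1 gives a limit of the assay, > 27000 nM, not a number. Compound 2 also gives a limit, > 27000 nM. Compound 3 gives a limit as well, > 27000 nM. Among the measured compounds shown here, all three sit at the same limit (the limit of > 27000 nM in this assay, at which 3 of the 3 values shown sit), so no step between measured compounds can be read off and compound 1 stands level with the others.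

The unmeasured compound 4 `Cc1ccc(N2CCN(C(=O)C3CCN(C(=O)c4ccc(S(C)(=O)=O)c([N+](=O)[O-])c4)CC3)CC2)cc1` differs from compound 1 in one place: methyl in place of fluoro on an aromatic carbon. With every measured compound at the limit, no direction can be drawn from the data; the step from compound 1 to compound 4 is expected to be none beyond the scatter, a number no higher from compound 1 to compound 4 (the limit leaves the size open). Compound 4 is therefore expected near 27000 nM, from 15000 nM to 60000 nM.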

Compound 4, half-maximal effective concentration: > 27000 nM
Compound 4 was reported as a limit; the forecaster's own chance of this, stated with the estimate: 80%; the middle value lies on the limit itself.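

Among the compounds shown here, compound 1 and compound 4 both give a limit of the assay rather than a number, so no step between them can be read: the limit of > 27000 nM in this assay, at which 4 of the 4 values shown sit. The compounds shown leave open whether fluoro or methyl at this place makes any difference in this assay.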